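Sulfonamide aryl change, compound 2 to compound 3

The source may report more compounds than this note shows. Statements on the series, on what has been measured and on what is new or still open speak of the compounds shown alone.

Among the compounds with values here, in a functional assay on DU-145 cells (Homo sapiens) for antiproliferative activity, read by MTT assay, with a stated time of 72 h (a higher number here means a weaker inhibitor, a lower number a stronger inhibitor), compound 1 (`CN(c1ccccc1Cl)S(=O)(=O)C1CC2OC1C(c1ccc(NC(=O)CCCCCCC(=O)O)cc1)=C2c1ccc(O)cc1`) gives 73500 nM and compound 2 (`CCN(c1ccc(Cl)cc1)S(=O)(=O)C1CC2OC1C(c1ccc(NC(=O)CCCCCCC(=O)O)cc1)=C2c1ccc(O)cc1`) gives 42100 nM as its value, so compound 2 stands within the scatter of the only other measured member. Within the data shown here, the one measured step is a 1.7-fold lower number from compound 1 to compound 2 (0.24 log units; within the scatter) and it stays within the scatter, although it exchanges (2-chlorophenyl)(methyl)amino for (4-chlorophenyl)(ethyl)amino on the sulfonyl sulfur.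

Compound 3 (`CCN(c1ccccc1Br)S(=O)(=O)C1CC2OC1C(c1ccc(NC(=O)CCCCCCC(=O)O)cc1)=C2c1ccc(O)cc1`) follows from compound 2 by the change 2-bromophenyl in place of 4-chlorophenyl on a sulfonamide nitrogen in which 2-bromophenyl takes the place of 4-chlorophenyl on a sulfonamide nitrogen whose other neighbours are a saturated chain carbon and the sulfonyl sulfur. The ethyl group stays. Among the measured compounds shown here, no bromine-bearing compound has been measured, so the closest guides are compound 2 and compound 1 with its 2-chlorophenyl group at 73500 nM in this series. Since the step of a 1.7-fold lower number from compound 1 to compound 2 (0.24 log units; within the scatter) remained within the scatter, no shift beyond the scatter is expected here. The estimated change is a 1.2-fold higher number from compound 2 to compound 3 (0.07 log units; within the scatter) and it is expected to stay within the scatter. For compound 3 the estimated value in this assay is 50000 nM with an expected range from 22000 nM to 100000 nM on this read-out.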

Compound 3, half-maximal inhibitory concentration: 95300 nM
Estimate against measurement, compound 3: 1.9-fold (0.28 log units) below; the measured number falls inside the stated range.
By their numbers in this assay, from the lowest: compounds 2, 1 and 3 (each within the scatter of the next, the first and the last beyond it).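

Within the data shown here, on the sulfonamide nitrogen that keeps its ethyl group, 2-bromophenyl in place of 4-chlorophenyl gives the first step beyond the scatter in this assay (a 2.3-fold higher number from compound 2 to compound 3 (0.35 log units; beyond the scatter)), though a modest one, so the number at this position does respond to the aryl group it carries. The comparison that also changes the chain on the nitrogen, with (2-bromophenyl)(ethyl)amino in place of (2-chlorophenyl)(methyl)amino on the sulfonyl sulfur, stays within the scatter (a 1.3-fold higher number from compound 1 to compound 3 (0.11 log units; within the scatter)), and any rule that a 2-halogenated phenyl group reads higher than 4-chlorophenyl is contradicted by compound 1, which lies within the scatter of compound 2. No measurement at hand gives a reason for either step.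

The step from 4-chlorophenyl to 2-bromophenyl alters the halogen and its place on the ring together, so the compounds shown do not separate the two contributions. Also open, from the compounds shown here alone, is how a plain phenyl, a 4-methoxyphenyl or a pyridinyl group on the same nitrogen would read in this assay against compound 2 at 42100 nM as the lowest number so far.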